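The source may report more compounds than this note shows. Statements on the series, on what has been measured and on what is new or still open speak of the compounds shown alone.

Measured compounds:
compound 1 `CNC(=O)c1cccc2nc(-c3c[nH]c4c(F)c(F)c(F)cc34)ccc12` — 1.17 h
compound 2 `Cc1cccc2c(-c3ccc4ccc(F)cc4n3)c[nH]c12` — 0.883 h

In an ADME assay on microsomes from liver (Homo sapiens) for metabolic stability, using NADPH, with a stated time of 40 min, tested at 2 uM (on this read-out higher numbers stand for a longer-lived compound and lower numbers for a shorter-lived compound), compound 1 gives 1.17 h and compound 2 gives 0.883 h. Within the data shown here, these two numbers lie within the usual scatter of each other, so neither compound can be set apart from the other on this read-out, and no step between two measured compounds that differ in one place is available as a guide.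

Compound 3 `Fc1cc2c(-c3ccc4c(C(F)(F)F)cccc4n3)c[nH]c2c(F)c1F` has not yet been measured. It derives from compound 1 by trifluoromethyl in place of methylcarbamoyl on an aromatic carbon. Among the measured compounds shown here, with no comparable step among the measured compounds, the expectation for this assay rests on the starting value alone: a step of a 1.1-fold higher number from compound 1 to compound 3 (0.05 log units; within the scatter) is expected, which is no shift beyond the scatter in either direction. On that basis compound 3 is estimated to give 1.3 h, within a range from 0.6 h to 2.8 h.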

Compound 3, half-life: 1.12 h
Beside the measured number, compound 3's estimate is 1.2-fold (0.06 log units) above it; the measured number falls inside the stated range.
By their numbers in this assay, from the lowest: compounds 2, 3 and 1 (each within the scatter of the next).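

In this assay trifluoromethyl in place of methylcarbamoyl on an aromatic carbon gives a 1.0-fold lower number from compound 1 to compound 3 (0.02 log units; within the scatter) and so leaves the two compounds indistinguishable on this read-out. This pair gives the first direct view of this position: a group with one hydrogen-bond donor and one hydrogen-bond acceptor gives way to a group with neither, and the half-lives still lie within the scatter of each other. For this pair, then, the half-life does not depend on keeping the amide hydrogen or the carbonyl. Nothing measured here explains this result. Still open, going by these compounds, is whether an amine, a carboxylic acid or a longer chain on the same aromatic carbon would also leave the half-life within the scatter. A single pair also cannot show whether the same swap would give a similar result on a different core.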